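The compounds below may be only part of what the source reports. "The series", "measured", "known", "first", "only" and "open" are said of these compounds alone.

Compound 1, `O=C(c1ccccc1)N1N=C(c2cccs2)CC1c1ccc(Cl)cc1`, was tested in a functional assay on BHK-21 cells (Mesocricetus auratus) for cytotoxicity, read by MTT assay; on this read-out lower numbers stand for higher toxicity in this test and higher numbers for lower toxicity in this test. In this assay compound 1 gives only a limit, > 300000 nM, and not a number. Compound 2, `O=C(c1ccccc1)N1N=C(c2cccs2)CC1c1ccc(Br)cc1`, likewise gives only a limit in this assay, > 300000 nM. Compound 3, `COc1ccc(C2CC(c3cccs3)=NN2C(=O)c2ccccc2)cc1`, also gives only a limit in this assay, > 300000 nM. The steps among these three, a step that the two limits leave unreadable from compound 1 to compound 2, a step that the two limits leave unreadable from compound 1 to compound 3 and a step that the two limits leave unreadable from compound 2 to compound 3, have no readable size; what unites them is the limit of > 300000 nM in this assay, at which 3 of the 3 values shown sit. Compound 4, `CC(C)(C)C(=O)N1N=C(c2cccs2)CC1c1ccc(Cl)cc1`, differs from compound 1 by tert-butyl in place of phenyl on a carbonyl carbon. For the measured compounds named here, none of the measured steps touches the carbonyl carbon; no measured step bears directly on this change, and the three limits give no direction. The expectation is that compound 4 also sits at the limit, with the step from compound 1 to compound 4 estimated as a number no higher from compound 1 to compound 4 (the limit leaves the size open). The value estimated for compound 4 is 300000 nM, between 100000 nM and 1000000 nM.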

Compound 4, half-maximal cytotoxic concentration: 90000 nM
Beside the measured number, compound 4's estimate is 3.3-fold (0.52 log units) above it; the measured number lies below the stated range.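

Placing tert-butyl in place of phenyl on the carbonyl carbon gives an at least 3.3-fold lower number from compound 1 to compound 4 (0.52 log units; beyond the scatter), so in this assay this position can shift the read-out towards higher toxicity in this test. For the compounds shown here, the steps among the chloro, bromo and methoxy compounds could not be read, which makes this the first readable step. Compound 4 gives a number, while the other compounds stay at a limit: the limit of > 300000 nM in this assay, at which 3 of the 4 values shown sit.

A single change cannot show whether the phenyl ring's departure or the arrival of tert-butyl matters more. Going by these compounds, how an amine, a carboxylic acid or a longer chain on that carbonyl carbon would behave remains open.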